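Acyl chain length on the ring nitrogen: propanoyl to acetyl

This account rests on a few compounds, and the source may have more. Where it says the series, first, only, none or still open, it means among the compounds named here.

Compound 1 `O=CN1N=C(c2ccc(F)cc2)CC1c1cn(-c2ccccc2)nc1-c1ccc(Cl)c(Cl)c1` carries a formyl group on an amine nitrogen in a ring of the shared core; in a functional assay on the whole organism (strain Wistar) for inhibition, with Rattus norvegicus as the target, read by paw edema, with a stated time of 30 min, at a dose of 50 mg/kg by the oral route (on this read-out higher numbers stand for more inhibition at the one dose given (going by the name of the read-out) and lower numbers for less inhibition), compound 1 gives 37.2%. Compound 2 `Fc1ccc(C2=NN(c3ccccc3)C(c3cn(-c4ccccc4)nc3-c3ccc(Cl)c(Cl)c3)C2)cc1` carries phenyl on that nitrogen, and compound 2 gives 44.7%. Compound 3 `CCC(=O)N1N=C(c2ccc(F)cc2)CC1c1cn(-c2ccccc2)nc1-c1ccc(Cl)c(Cl)c1` carries propanoyl there, and compound 3 gives 51.1%. Compound 3 stands highest of the three numbers, but only its distance from compound 1 counts: a number 13.9 percentage points higher from compound 1 to compound 3 (beyond the scatter), whereas a number 6.4 percentage points higher from compound 2 to compound 3 (within the scatter) and a number 7.5 percentage points higher from compound 1 to compound 2 (within the scatter).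

Compound 4 `CC(=O)N1N=C(c2ccc(F)cc2)CC1c1cn(-c2ccccc2)nc1-c1ccc(Cl)c(Cl)c1` shortens the acyl chain. (hydrogen in place of methyl on a saturated chain carbon bound to a carbonyl carbon). Among the compounds with values here, the one measured step that bears on this is the change from formyl to propanoyl, a number 13.9 percentage points higher from compound 1 to compound 3 (beyond the scatter), which runs from hydrogen through the missing methyl to ethyl on a carbonyl carbon; compound 4 sits on that same line, its number expected between those of compound 1 and compound 3. Within the data shown here, no other measured pair touches the carbonyl chain, so there is nothing to set the acetyl analogue apart from a simple intermediate. A modest fall is therefore expected, a number 6.1 percentage points lower from compound 3 to compound 4 (within the scatter), of a size that need not exceed the scatter. Compound 4 is estimated at 45%, with a range from 35% to 55%.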

Compound 4, a percentage reported as inhibition, in the whole organism at one dose (the size of the read-out at that dose, not a potency): 45.7%
Beside the measured number, compound 4's estimate is 0.7 percentage points below it; measured number inside the range.
By their numbers in this assay, from the lowest: compounds 1, 2, 4 and 3 (each within the scatter of the next, the first and the last beyond it).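

In this assay the chain on the carbonyl carbon now has three points, and the step of a number 13.9 percentage points higher from compound 1 to compound 3 (beyond the scatter) breaks into a number 8.5 percentage points higher from compound 1 to compound 4 (within the scatter) and a number 5.4 percentage points lower from compound 3 to compound 4 (within the scatter) with neither part beyond the scatter on its own. Acetyl and phenyl on the amine nitrogen in a ring stand level, with a number 1 percentage points higher from compound 2 to compound 4 (within the scatter) as the step, so this pair does not set an acyl group on that nitrogen apart from phenyl. No measurement on these compounds accounts for any of these steps.

On these data alone, whether an acyl chain longer than propanoyl, such as butanoyl or pentanoyl, or a benzoyl group on that nitrogen would give a number clear of the scatter from compound 3 stays open. With one dose and one time point, the read-out gives only the size of the effect at that dose, so it gives no potency and cannot separate compounds 2, 3 and 4, whose numbers lie within the scatter of one another.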